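Replacing the Ethylpyrazole with Benzothiophene: Expected Clearance

This account rests on a few compounds, and the source may have more. Where it says the series, first, only, none or still open, it means among the compounds named here.

Three compounds have been measured in an ADME assay (liver) for metabolic stability, with Liver microsome (Homo sapiens) as the target, using microsomes and NADPH, with a stated time of 30 min, tested at 1 uM; on this read-out lower numbers stand for slow clearance and higher numbers for fast clearance:
Compound 1 `Nc1ccc(S(=O)(=O)N2CCN(c3ncc(C(O)(C(F)(F)F)C(F)(F)F)cc3C3CC3)CC2)cn1` gives 38 mL.min-1.g-1.
Compound 2 `CCn1cc(-c2cc(C(O)(C(F)(F)F)C(F)(F)F)cnc2N2CCN(S(=O)(=O)c3ccc(N)nc3)CC2)cn1` gives 20 mL.min-1.g-1.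
Compound 3 `NC(=O)c1cccc(-c2cc(C(O)(C(F)(F)F)C(F)(F)F)cnc2N2CCN(S(=O)(=O)c3ccc(N)nc3)CC2)c1` gives 17 mL.min-1.g-1.

Compound 2 stands second highest of the three numbers, with both its neighbours within the scatter: a 1.2-fold lower number from compound 2 to compound 3 (0.07 log units; within the scatter) and, in the other direction, a 1.9-fold lower number from compound 1 to compound 2 (0.28 log units; within the scatter). Compound 4 `Nc1ccc(S(=O)(=O)N2CCN(c3ncc(C(O)(C(F)(F)F)C(F)(F)F)cc3-c3ccc4sccc4c3)CC2)cn1` has not yet been measured. It differs from compound 2 in a single place: 1-benzothiophen-5-yl in place of 1-ethyl-1H-pyrazol-4-yl on an aromatic carbon. The earlier swaps at this same aromatic carbon are the relevant guides, and both were small, the largest being a 2.2-fold lower number from compound 1 to compound 3 (0.35 log units; beyond the scatter). A 1-benzothiophen-5-yl entering at that carbon is therefore expected to move the number only modestly, as a 1.6-fold higher number from compound 2 to compound 4 (0.20 log units; within the scatter), toward faster clearance. Compound 4 is estimated at 32 mL.min-1.g-1, within a range of 16 mL.min-1.g-1 to 65 mL.min-1.g-1.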

Compound 4, intrinsic clearance in microsomes: 48 mL.min-1.g-1
The estimate for compound 4 lay 1.5-fold (0.18 log units) below the measured number; measured number inside the range.
By their numbers in this assay, from the lowest: compounds 3, 2, 1 and 4 (each within the scatter of the next, the first and the last beyond it).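

In this assay, this aromatic carbon can also move the number upward beyond the scatter: 1-benzothiophen-5-yl gives a 2.4-fold higher number from compound 2 to compound 4 (0.38 log units; beyond the scatter) and a 2.8-fold higher number from compound 3 to compound 4 (0.45 log units; beyond the scatter). An aromatic group here therefore does not by itself keep clearance low, since against cyclopropyl the change is only a 1.3-fold higher number from compound 1 to compound 4 (0.10 log units; within the scatter). Nothing available explains this rise.

From the compounds shown here alone, it remains open whether the higher number goes with the sulfur or with the fused second ring. A plain phenyl or a naphthyl group at this carbon would help separate the two.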